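The source may report more compounds than this note shows. Statements on the series, on what has been measured and on what is new or still open speak of the compounds shown alone.

Compound 1 `COc1cc(-c2nn(-c3cccc(NC(=O)Nc4cc(C(F)(F)F)cc(C(F)(F)F)c4)c3)cc2-c2ccncc2)ccc1Cl`: 2730 nM
Compound 2 `COc1cc(-c2nn(-c3cccc(NC(=O)c4cccc(C(F)(F)F)c4)c3)cc2-c2ccncc2)ccc1Cl`: a limit, > 50000 nM

In a functional assay on UO-31 cells (Homo sapiens) for inhibition, read by sulforhodamine B assay, with a stated time of 48 h (a lower number here means that less compound is tolerated, a higher number that more compound is tolerated), compound 1 gives 2730 nM. For compound 2 this assay reports only a limit, > 50000 nM, so compound 2 stands at the edge of what was measured, as the limit of > 50000 nM in this assay, at which 1 of the 2 values shown sits, records. Compound 3 `COc1cc(-c2nn(-c3cccc(NC(=O)c4ccc(Cl)c(C(F)(F)F)c4)c3)cc2-c2ccncc2)ccc1Cl` has not yet been tested in this assay. It differs from compound 2 in one place: chloro in place of hydrogen on an aromatic carbon. Among the measured compounds shown here, no step between two measured compounds is available here, so the size of the change is open; a modest move toward a lower number is expected, one that the limit on compound 2 makes hard to size and that may not exceed the scatter. Compound 3 is expected to give 35000 nM in this assay, between 8000 nM and 50000 nM, a step of an at least 1.4-fold lower number from compound 2 to compound 3 (0.15 log units; that floor lies within the scatter).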

Compound 3, concentration lethal to 50% of the cells: > 32500 nM
Compound 3: a limit, no number (the forecaster's own chance of this, stated with the estimate: 55%); the middle value lies beyond the limit too.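

In this assay compound 3 gives > 32500 nM, which is a limit. Compound 2 likewise gives a limit, > 50000 nM. No step can be read from compound 2 to compound 3. The compounds shown leave open whether chloro in place of hydrogen changes the value at all.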